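Methoxy to hydroxy on a pyrrolidine scaffold: expected flat

The compounds below may be only part of what the source reports. "The series", "measured", "known", "first", "only" and "open" are said of these compounds alone.

Of the compounds shown here, three sharing a polyhydroxylated core have been tested in an assay on isolated protein for inhibition of alpha-galactosidase (Coffea arabica), tested at 1000 uM; a higher number here means more inhibition at the concentration tested (going by the name of the read-out), a lower number less inhibition. Compound 1 `OC[C@]1(c2ccc(F)cc2)NC[C@H](O)[C@H]1O` gives 0% in this assay. Compound 2 `COc1ccc([C@]2(CO)NC[C@@H](O)[C@@H]2O)cc1` gives 7.5% in this assay, and compound 3 `CCCCCCCCC[C@]1(CO)NC[C@@H](O)[C@@H]1O` gives 2.5% in this assay. Compound 2 shows the highest of the three numbers, but its gaps to compound 3 and to compound 1 both fall within the usual scatter of such measurements, so the three readings are indistinguishable and all sit close to no inhibition.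

Compound 4 `OC[C@@]1(c2ccc(O)cc2)NC[C@@H](O)[C@@H]1O` has not yet been measured. It differs from compound 2 in one place: hydrogen in place of methyl on an oxygen on an aromatic ring. Among the measured compounds shown here, no pair of measured compounds records a single change of this kind, so nothing directly shows what it does. Because compound 1 gives 0% and compound 2 gives 7.5%, both near zero, a step of a number 2.5 percentage points lower from compound 2 to compound 4 (within the scatter) is expected, that is, no change beyond the scatter. Compound 4 is estimated at 5%, within a range from 0% to 20%.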

Compound 4, a percentage reported as inhibition, at one concentration (the size of the read-out at that concentration, not a potency): 1.2%
Compound 4: middle estimate off by 3.8 percentage points, on the high side, and the stated range covers the measured number.
By their numbers in this assay, from the lowest: compounds 1, 4, 3 and 2 (each within the scatter of the next).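

Among the compounds shown here, this is the first direct reading of a single change at this place: on an oxygen on an aromatic ring, going from methoxy to hydroxy gives a number 6.3 percentage points lower from compound 2 to compound 4 (within the scatter) in this assay for this pair. Removing the methyl therefore produces no change that can be told from the scatter, and both compounds stay close to no inhibition. Nothing measured here bears on the reason for this result.

The compounds shown leave open whether any other group at this place, such as an amine or a carboxylic acid in place of the hydroxy, could lift the reading clear of the scatter. As far as these compounds go, with all readings this close to no inhibition, a loss could hardly show, so the effect of this change on a compound that inhibits more strongly also remains unknown.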